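Aryl exchange at compound 3 in the series

The source may hold more compounds than are shown below. What is called first, only, known or untested is meant among the compounds shown, and "the series" means these compounds.

Among the measured compounds shown here, in an ADME assay on ECV-304 cells (Homo sapiens) for cytotoxicity, read by MTT assay, with a stated time of 72 h (on this read-out lower numbers stand for stronger inhibition and higher numbers for weaker inhibition), compound 3 (`COc1cc(C2=C(c3cc(C)c(OC)c(C)c3)C(O[SiH2]C(C)(C)C)CC2=O)cc(OC)c1OC`) gives 15 ug/mL, the only number so far. Compound 1 (`COC(=O)c1cc(C2=C(c3cc(OC)c(OC)c(OC)c3)C(=O)CC2O[SiH2]C(C)(C)C)ccc1OC`) reads > 100 ug/mL, which is a limit. Compound 2 (`COc1cc(C2=C(c3ccccc3)C(O[SiH2]C(C)(C)C)CC2=O)cc(OC)c1OC`) reads > 100 ug/mL, also a limit. Compound 3 thus stands alone away from the limit of > 100 ug/mL in this assay, at which 2 of the 3 values shown sit.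

Compound 4 (`COc1ccc(C2=C(c3cc(OC)c(OC)c(OC)c3)C(=O)CC2O[SiH2]C(C)(C)C)cc1O`) carries 3-hydroxy-4-methoxyphenyl in place of 4-methoxy-3,5-dimethylphenyl on a double-bonded ring carbon.

Two measured steps change this same place: an at least 6.6-fold lower number from compound 1 to compound 3 (0.82 log units; beyond the scatter), and an at least 6.6-fold lower number from compound 2 to compound 3 (0.82 log units; beyond the scatter). They show that the number moves with this group, but neither involves the entering group, so they give no direction. The expected result is a 1.5-fold lower number from compound 3 to compound 4 (0.18 log units; within the scatter), with no shift beyond the scatter anticipated. For compound 4 the estimated value is 10 ug/mL, with an expected range of 0.7 ug/mL to 80 ug/mL.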

Compound 4, half-maximal inhibitory concentration: 30 ug/mL
The estimate for compound 4 lay 3.0-fold (0.48 log units) below the measured number; measured number inside the range.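

At this place, 3-hydroxy-4-methoxyphenyl and 4-methoxy-3,5-dimethylphenyl read alike, with a 2.0-fold higher number from compound 3 to compound 4 (0.30 log units; within the scatter). Among the compounds shown here, a second aryl group therefore gives a number clear of the limit, and compound 4 is the first to show a change on the aryl ring itself, hydroxy for methoxycarbonyl. The two further steps, an at least 3.3-fold lower number from compound 2 to compound 4 (0.52 log units; beyond the scatter) and an at least 3.3-fold lower number from compound 1 to compound 4 (0.52 log units; beyond the scatter), each start from a limit and not from a number: the limit of > 100 ug/mL in this assay, at which 2 of the 4 values shown sit.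

Still open, on these data alone, is whether an amine or a carboxylic acid in place of the hydroxy of compound 4 stays clear of that limit in this assay. Also open, as far as these compounds go, is what a single methyl group gives in place of the two in compound 3.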